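The source may hold more compounds than are shown below. What is called first, only, known or untested is meant among the compounds shown, and "the series" means these compounds.

Compound 1, `COc1cc2nc(N3CCN(S(=O)(=O)c4ccc(Cl)cc4)CC3)nc(N)c2cc1OC`: 23000 nM
Compound 2, `COc1cc2nc(N3CCN(S(=O)(=O)c4ccc(Br)cc4)CC3)nc(N)c2cc1OC`: 20000 nM
Compound 3, `COc1cc2nc(N3CCN(S(=O)(=O)c4ccc(I)cc4)CC3)nc(N)c2cc1OC`: 15000 nM

These three compounds share one core and differ only in the halogen carried on the aromatic ring attached to the sulfonyl sulfur. In a functional assay on PC-3 cells (Homo sapiens) for inhibition (a lower number here means a stronger inhibitor, a higher number a weaker inhibitor), compound 3 stands at the low end of the three numbers, but only nominally: a 1.3-fold lower number from compound 2 to compound 3 (0.12 log units; within the scatter) and a 1.5-fold lower number from compound 1 to compound 3 (0.19 log units; within the scatter) both lie within the scatter, as does a 1.2-fold lower number from compound 1 to compound 2 (0.06 log units; within the scatter). On these numbers compound 3 cannot be called a stronger inhibitor than compound 1 or compound 2.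

Compound 4, `COc1cc2nc(N3CCN(S(=O)(=O)c4ccc(Cl)s4)CC3)nc(N)c2cc1OC`, has not yet been measured. It differs from compound 3 by 5-chlorothiophen-2-yl in place of 4-iodophenyl on a sulfonyl sulfur. Among the compounds with values here, none of the measured steps exchanges the ring itself; each swaps one halogen for another, and each stayed within the scatter. They bear on the new step only in showing that changes to the group on the sulfonyl sulfur have so far moved this assay little. From the compounds shown here alone, the replacement of the whole ring is untested, so a larger shift in either direction cannot be excluded, yet the expectation is a step no larger than the scatter, a 1.3-fold higher number from compound 3 to compound 4 (0.12 log units; within the scatter). Compound 4 is therefore estimated at 20000 nM, with a range from 7000 nM to 60000 nM.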

Compound 4, half-maximal inhibitory concentration: 25000 nM
Estimate against measurement, compound 4: 1.3-fold (0.10 log units) below, and the stated range covers the measured number.
By their numbers in this assay, from the lowest: compounds 3, 2, 1 and 4 (each within the scatter of the next).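

In this assay, exchanging the whole ring on the sulfonyl sulfur, and not only its halogen, gives a 1.7-fold higher number from compound 3 to compound 4 (0.22 log units; within the scatter) and a 1.3-fold higher number from compound 2 to compound 4 (0.10 log units; within the scatter) and a 1.1-fold higher number from compound 1 to compound 4 (0.04 log units; within the scatter) as its three steps, so compound 4 cannot be told apart from compound 1, compound 2 or compound 3. At this position, a five-membered aromatic ring with 1 hetero atom therefore reads the same as a six-membered aromatic ring of carbon only, and the hydrogen-bond acceptor counted in 5-chlorothiophen-2-yl brings no step beyond the scatter. No measurement shown here offers a reason for this flat picture.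

Every group shown on the sulfonyl sulfur is an aromatic ring carrying a halogen, so it remains open whether an aromatic ring with no halogen, a ring carrying an amine or a carboxylic acid, or a plain alkyl chain would move the number beyond the scatter. Also open, from the compounds shown here alone, is whether a carbonyl in place of the sulfonyl, or any change to the shared core, would do so.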